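Enlarging the side-chain ring of compound 3

The source may hold more compounds than are shown below. What is called first, only, known or untested is meant among the compounds shown, and "the series" means these compounds.

In a functional assay on MDA-MB-231 cells (Homo sapiens) for antiproliferative activity, read by MTT assay, with a stated time of 48 h (on this read-out lower numbers stand for stronger inhibition and higher numbers for weaker inhibition), compound 1 `C=CS(=O)(=O)N1CCN(c2ncnc3sc(-c4ccc(C#N)cc4)cc23)CC1` gives 8050 nM, compound 2 `C=CS(=O)(=O)N1CCN(c2ncnc3sc(-c4ccnc(Cl)c4)cc23)CC1` gives 27700 nM and compound 3 `C=CS(=O)(=O)N1CCN(c2nc(OC[C@H]3CCCN3C)nc3sc(-c4ccc(C#N)cc4)cc23)CC1` gives 3010 nM, the lowest number of the three. Compound 4 `C=CS(=O)(=O)N1CCN(c2nc(OCC3CCCCN3C)nc3sc(-c4ccc(C#N)cc4)cc23)CC1` is not yet measured. It carries 1-methylpiperidin-2-yl in place of 1-methylpyrrolidin-2-yl on a saturated chain carbon bound to an oxygen on an aromatic ring. The nearest evidence is a 2.7-fold lower number from compound 1 to compound 3 (0.43 log units; beyond the scatter), which comes with adding the whole (1-methylpyrrolidin-2-yl)methoxy group. The other step, a 3.4-fold higher number from compound 1 to compound 2 (0.54 log units; beyond the scatter), concerns a different place. Neither step tests this ring change directly, so a small step is expected, none beyond the scatter. The expected step is a 1.2-fold higher number from compound 3 to compound 4 (0.07 log units; within the scatter). Compound 4 is estimated at 3500 nM, with an expected range from 1400 nM to 8000 nM.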

Compound 4, half-maximal inhibitory concentration: 3180 nM
Compound 4: the middle estimate sits 1.1-fold (0.04 log units) above what was measured; the range from low to high includes it.
By their numbers in this assay, from the lowest: compounds 3 and 4 (each within the scatter of the next); then compound 1; then compound 2.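

In this assay, 1-methylpiperidin-2-yl can stand in place of 1-methylpyrrolidin-2-yl with only a 1.1-fold higher number from compound 3 to compound 4 (0.02 log units; within the scatter) on this saturated chain carbon, so the two rings cannot be told apart here. The drop in number that comes with adding the side chain to the core is thus not confined to the five-membered ring, since a 2.5-fold lower number from compound 1 to compound 4 (0.40 log units; beyond the scatter) appears with the six-membered ring as well. No evidence bearing on this result is available. On these data alone, whether a morpholine ring or an open dimethylamino chain would give similar numbers remains open. So does whether either side chain gives a comparable step with 2-chloropyridin-4-yl in place of 4-cyanophenyl.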